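Cytotoxicity limit: pyridin-3-yl to 3-(methylsulfonyl)phenyl

The compounds below may be only part of what the source reports. "The series", "measured", "known", "first", "only" and "open" are said of these compounds alone.

Of the compounds shown here, three sharing one core have been read in a functional assay on HEK293 cells (Homo sapiens) for cytotoxicity (a higher number here means that more compound is tolerated, a lower number that less compound is tolerated), and none gives a number. Compound 1 `COc1ccc([C@H]2CC(=O)N(c3cccc(C#N)c3)C2)cc1OC1CCCC1`, with 3-cyanophenyl on the amide-type nitrogen in a ring, gives only a limit, > 10000 nM. Compound 2 `COc1ccc([C@H]2CC(=O)N(c3ccccc3C)C2)cc1OC1CCCC1`, with 2-methylphenyl at that place, also gives only a limit, > 10000 nM. Compound 3 `COc1ccc([C@H]2CC(=O)N(c3cccnc3)C2)cc1OC1CCCC1`, with pyridin-3-yl there, likewise stands at a limit, > 10000 nM.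

The next change leads to compound 4 `COc1ccc([C@H]2CC(=O)N(c3cccc(S(C)(=O)=O)c3)C2)cc1OC1CCCC1`, in which 3-(methylsulfonyl)phenyl takes the place of pyridin-3-yl on the same nitrogen: 3-(methylsulfonyl)phenyl in place of pyridin-3-yl on an amide-type nitrogen in a ring.

Three measured exchanges at this place bear on the change: a step that the two limits leave unreadable from compound 1 to compound 2, a step that the two limits leave unreadable from compound 1 to compound 3 and a step that the two limits leave unreadable from compound 2 to compound 3. None of them has a readable size, and the whole record is the limit of > 10000 nM in this assay, at which 3 of the 3 values shown sit. Within the data shown here, no measured step therefore sets a size or direction for this exchange in this assay. The expectation rests on compound 3, whose > 10000 nM is a limit. The expected change is a step that the limit leaves unreadable from compound 3 to compound 4, taken as none beyond the scatter. For compound 4 the estimate is 15000 nM, with an expected range of 7000 nM to 40000 nM, and the reading will most likely be another limit.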

Compound 4, half-maximal cytotoxic concentration: > 10000 nM
Compound 4: no number, only a limit; the forecaster's own chance of this, stated with the estimate: 90%; the middle value lies beyond the limit too.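

In this assay, among these compounds, compound 4 gives > 10000 nM, again a limit and not a number, so no step between it and compound 1, compound 2 or compound 3 can be read: the limit of > 10000 nM in this assay, at which 4 of the 4 values shown sit. The compounds shown leave open at what concentration any of them becomes cytotoxic, and whether the group on the amide-type nitrogen in a ring changes that concentration.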